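Nitrophenyl in Place of Pyridyl at the Chain Terminus

This account rests on a few compounds, and the source may have more. Where it says the series, first, only, none or still open, it means among the compounds named here.

Measured compounds:
compound 1 `O=C(/C=C/c1ccc(Oc2cc(=O)oc3ccccc23)cc1)/C=C/c1ccccn1` — 50800 nM
compound 2 `O=C(/C=C/c1ccc(Oc2cc(=O)oc3ccccc23)cc1)/C=C/c1cccnc1` — 37000 nM
compound 3 `COc1cc(OC)c2c(=O)c(OCCCOc3ccccc3/C=C/C(=O)/C=C/c3ccccn3)c(-c3cc(OC)c(OC)c(OC)c3)oc2c1` — 3930 nM

In a functional assay on U-87MG ATCC cells for antiproliferative activity against U-87 MG (Homo sapiens), read by MTT assay, with a stated time of 48 h (on this read-out lower numbers stand for stronger inhibition and higher numbers for weaker inhibition), compound 3 stands lowest of the three numbers, with compound 2 and compound 1 both well beyond the scatter above it. Compound 4, `COc1cc(OC)c2c(=O)c(OCCCOc3ccccc3/C=C/C(=O)/C=C/c3cccc([N+](=O)[O-])c3)c(-c3cc(OC)c(OC)c(OC)c3)oc2c1`, differs from compound 3 by 3-nitrophenyl in place of pyridin-2-yl on a double-bonded chain carbon bound to a double-bonded chain carbon. Going by the values given here, the only measured step touching this terminus is a 1.4-fold lower number from compound 1 to compound 2 (0.14 log units; within the scatter), which moved the ring nitrogen and changed nothing beyond the scatter. Among the compounds with values here, no measured step exchanges the pyridyl for a phenyl or introduces a nitro group, so the expectation rests on that single small step. For compound 4 the step of a 1.1-fold higher number from compound 3 to compound 4 (0.03 log units; within the scatter) is therefore expected to stay within the scatter. Compound 4 is estimated at 4200 nM, with a range from 1500 nM to 12000 nM.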

Compound 4, half-maximal inhibitory concentration: 7920 nM
Estimate against measurement, compound 4: 1.9-fold (0.28 log units) below; the range from low to high includes it.
By their numbers in this assay, from the lowest: compounds 3 and 4 (each within the scatter of the next); then compounds 2 and 1 (each within the scatter of the next).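

In this assay, 3-nitrophenyl in place of pyridin-2-yl on a double-bonded chain carbon bound to a double-bonded chain carbon gives a 2.0-fold higher number from compound 3 to compound 4 (0.30 log units; within the scatter) and so stays within the scatter. The earlier step only moved the ring nitrogen, whereas this one shows that the terminus tolerates a ring of carbon only, carrying a nitro group, with 9 heavy atoms in place of 6. Nothing available explains this result. Going by these compounds, whether an unsubstituted phenyl, an amine or a carboxylic acid at this terminus would read alike remains open. So does whether the same exchange would hold on the core of compound 1.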